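Small N-substituents on a shared core against adenosine A2b

The source may report more compounds than this note shows. Statements on the series, on what has been measured and on what is new or still open speak of the compounds shown alone.

Measured compounds:
compound 1 `CCCn1cnc2ncnc(N)c21` in a functional assay on CHO cells for antagonist activity at adenosine receptor A2b (Homo sapiens) (a higher number here means a weaker inhibitor, a lower number a stronger inhibitor), gives > 30000 nM.
compound 2 `CC(C)n1cnc2ncnc(N)c21` in this assay gives > 30000 nM.

Both values are limits of the assay, not numbers. For compound 1 the value > 30000 nM is such a limit. For compound 2 the value > 30000 nM is likewise a limit. The step that the two limits leave unreadable from compound 1 to compound 2 therefore cannot be read, and compound 2 stands only at the limit of this assay, where the limit of > 30000 nM in this assay, at which 2 of the 2 values shown sit, sits.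

Compound 3 `Nc1ncnc2ncn(CCO)c12` differs from compound 2 in one place: 2-hydroxyethyl in place of isopropyl on an aromatic nitrogen

Among the compounds with values here, no measured step bears directly on this change; the single step between compound 1 and compound 2 is itself unreadable, so no size or direction can be carried over. With compound 2 at the limit, the expectation for compound 3 rests on that limit alone. The estimated step that the limit leaves unreadable from compound 2 to compound 3 is expected to stay within the scatter. Compound 3 is therefore estimated at 40000 nM, within a range from 10000 nM to 150000 nM, and this assay is expected most likely to report only a limit for compound 3 again.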

Compound 3, inhibition constant: > 30000 nM
Compound 3 ended at the assay's limit (the forecaster's own chance of this, stated with the estimate: 85%); the middle value lies beyond the limit too.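

In this assay compound 3 gives > 30000 nM, again a limit and not a number. No step among compound 1, compound 2 and compound 3 can be read, and all three stand together: the limit of > 30000 nM in this assay, at which 3 of the 3 values shown sit.

The compounds shown leave open whether any substituent at this aromatic nitrogen of the shared core would give a measurable value in this assay.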